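Adding a Methyl to the Carbamate Side Chain

The compounds below may be only part of what the source reports. "The series", "measured", "known", "first", "only" and "open" are said of these compounds alone.

Three measured compounds share one core and differ only in the group on the carbamate oxygen. Compound 1 `CC(OC(=O)N1CCN(C(=O)c2nc(Nc3cc(C4CC4)[nH]n3)c3cc(Cl)ccc3n2)C[C@H]1C)OC(=O)C(C)(C)C` gives 66.3% in an ADME assay on S9 fraction from liver (Rattus norvegicus), read by LC-MS, with a stated time of 60 min, at 37 degrees C; a higher number here means that more of the compound is left, a lower number that less of the compound is left. Compound 2 `C[C@@H]1CN(C(=O)c2nc(Nc3cc(C4CC4)[nH]n3)c3cc(Cl)ccc3n2)CCN1C(=O)OCOC(=O)C(C)(C)C` gives 47%, and compound 3 `CCOC(=O)N1CCN(C(=O)c2nc(Nc3cc(C4CC4)[nH]n3)c3cc(Cl)ccc3n2)C[C@H]1C` gives 48.5% in this assay. The change methyl in place of hydrogen on a saturated chain carbon bound to two oxygens next to a carbonyl group made a number 19.3 percentage points higher from compound 2 to compound 1 (beyond the scatter). Compound 1 and compound 3 lie apart by a number 17.8 percentage points lower from compound 1 to compound 3 (beyond the scatter), while compound 2 and compound 3 differ by methyl in place of ((tert-butyl)carbonyl)oxy on a saturated chain carbon bound to an oxygen next to a carbonyl group, giving a number 1.5 percentage points higher from compound 2 to compound 3 (within the scatter). Compound 4 `CC(C)OC(=O)N1CCN(C(=O)c2nc(Nc3cc(C4CC4)[nH]n3)c3cc(Cl)ccc3n2)C[C@H]1C` arises from compound 3 by methyl in place of hydrogen on a saturated chain carbon bound to an oxygen next to a carbonyl group and a saturated chain carbon, the same kind of change as before, though here the carbon is bound to an oxygen next to a carbonyl group and a saturated chain carbon rather than to two oxygens. This expectation rests on a number 19.3 percentage points higher from compound 2 to compound 1 (beyond the scatter) and on the differing place, so a smaller move is expected. Compound 4 is expected to shift by a number 6.5 percentage points higher from compound 3 to compound 4 (within the scatter). Compound 4 is thus expected near 55% in this assay, between 40% and 70%.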

Compound 4, percent of the compound remaining: 78.6%
Compound 4: middle estimate off by 23.6 percentage points, on the low side; the measured number lies above the stated range.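

Methyl in place of hydrogen gives a number 30.1 percentage points higher from compound 3 to compound 4 (beyond the scatter) in this assay and, as on the other side chain, the number rises by an amount that agrees across the two cases: the same change on two cores in this assay, a number 19.3 percentage points higher (beyond the scatter) from compound 2 to compound 1 and a number 30.1 percentage points higher (beyond the scatter) from compound 3 to compound 4, 10.8 percentage points apart, within the scatter of two such steps. Methyl in place of ((tert-butyl)carbonyl)oxy gives a number 12.3 percentage points higher from compound 1 to compound 4 (beyond the scatter) and also agrees with its earlier step: the same change on two cores in this assay, a number 1.5 percentage points higher (within the scatter) from compound 2 to compound 3 and a number 12.3 percentage points higher (beyond the scatter) from compound 1 to compound 4, 10.8 percentage points apart, within the scatter of two such steps. Among these compounds, the whole side-chain swap gives a number 31.6 percentage points higher from compound 2 to compound 4 (beyond the scatter) and leaves compound 4 highest of the four, yet with only two pairs per change this shows agreement on these closely related carbamates, not that either change would carry over to other cores.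

The compounds shown leave open how a longer chain such as n-propyl on the carbamate oxygen would behave. From the compounds shown here alone, a cyclobutyl group there is equally open.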